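A few compounds are considered here, and "the series" means these few. Any claim that something is new, unique, unknown or untested is made for them only; others in the source may bear on it.

Measured compounds in this series:
- compound 1 `CCc1nncn1-c1ccc(OCc2ccccc2)cc1`: in a functional assay on the whole organism (strain C57B/6) with Mus musculus as the target, in the maximal electroshock model (a lower number here means that less compound is needed, a higher number that more compound is needed for the effect), compound 1 gives 20.8 mg/kg
- compound 2 `CCc1nncn1-c1ccc(OCc2ccccc2Cl)cc1`: compound 2 gives 13.2 mg/kg
- compound 3 `CCCCOc1ccc(-n2cnnc2CC)cc1`: compound 3 gives > 100 mg/kg, which is a limit of the assay and not a number

Compound 3 therefore stands only as a limit, with no number behind it (the limit of > 100 mg/kg in this assay, at which 1 of the 3 values shown sits). Its two neighbours differ from it by the group on the ether oxygen: an at least 4.8-fold higher number from compound 1 to compound 3 (0.68 log units; beyond the scatter) and an at least 7.5-fold higher number from compound 2 to compound 3 (0.87 log units; beyond the scatter). Between compound 1 and compound 2 the step is a 1.6-fold lower number from compound 1 to compound 2 (0.20 log units; within the scatter).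

Compound 4 `CCCCCCOc1ccc(-n2cnnc2CC)cc1` is not yet measured. It differs from compound 3 by ethyl in place of hydrogen on a saturated chain carbon, four bonds along the chain from an oxygen on an aromatic ring. Going by the values given here, no measured step bears directly on lengthening this chain; the two steps into compound 3 concern swapping an aromatic group for an alkyl one, not chain length, and both end at the limit. Among the compounds with values here, nothing among the measured compounds points to a return of activity from adding carbons to the chain, so compound 4 is expected to stay near the limit, with an estimated step that the limit leaves unreadable from compound 3 to compound 4. The estimate for compound 4 is 150 mg/kg, in the range 50 mg/kg to 400 mg/kg.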

Compound 4, dose for half-maximal effect: 13.2 mg/kg
Estimate against measurement, compound 4: 11-fold (1.06 log units) above; the whole stated range lies above it.
By their numbers in this assay, from the lowest: compounds 2, 4 and 1 (each within the scatter of the next). At a limit, above all of these: compound 3.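

Working from this assay, chain length on the ether oxygen proves decisive: adding ethyl four bonds along the chain from the oxygen on the aromatic ring gives an at least 7.5-fold lower number from compound 3 to compound 4 (0.87 log units; beyond the scatter). The reading for compound 3 is a limit and not a number, so this step has only a bound: the limit of > 100 mg/kg in this assay, at which 1 of the 4 values shown sits. An aromatic group on the saturated chain carbon bound to the oxygen is also not required in these compounds, since pentyl in that place gives no change at the digits printed from compound 2 to compound 4 (within the scatter) and a 1.6-fold lower number from compound 1 to compound 4 (0.20 log units; within the scatter).

Open, from the compounds shown here alone, is whether a longer chain such as octyl, or a chain ending in an amine, would keep this number. Going by these compounds, the ethyl on the shared core is the same in all four compounds, so the effect of a methyl or propyl there remains unknown.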